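The source may report more compounds than this note shows. Statements on the series, on what has been measured and on what is new or still open speak of the compounds shown alone.

Measured compounds:
- compound 1, `OC[C@H]1O[C@@H](n2cnc3c(NCc4ccccc4Cl)ncnc32)[C@H](O)[C@@H]1O`: "not determined" (no result reported)
- compound 2, `OC[C@H]1O[C@@H](n2cnc3c(NCc4ccc(Br)cc4)ncnc32)[C@H](O)[C@@H]1O`: > 166000 nM

The account concerns a functional assay on G-361 cells (Homo sapiens) for antiproliferative activity, with a stated time of 72 h (on this read-out higher numbers stand for weaker inhibition and lower numbers for stronger inhibition), and the step from compound 1 to the untested compound 3, `OC[C@H]1O[C@@H](n2cnc3c(NCc4ccc(Cl)c(Cl)c4)ncnc32)[C@H](O)[C@@H]1O`. Compound 1 stands without any single number in this assay, so it offers no fixed point. Compound 2 reaches only a limit of the assay, > 166000 nM, and not a number; this is the limit of > 166000 nM in this assay, at which 1 of the 2 values shown sits. The change from compound 1 to compound 3 is 3,4-dichlorophenyl in place of 2-chlorophenyl on a saturated chain carbon bound to a nitrogen on an aromatic ring. Within the data shown here, no step between two measured compounds is available, so no direction or size of effect can be read from the data, and any shift is as likely to fall within the scatter as beyond it. Against this background, compound 3 is expected to sit at about 150000 nM, with a plausible range from 30000 nM to 500000 nM, and a result reported only as a limit seems quite likely.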

Compound 3, half-maximal inhibitory concentration: 145000 nM
Compound 3: middle estimate off by 1.0-fold (0.01 log units), on the high side; the range from low to high includes it.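

In this assay, among these compounds, compound 3 gives 145000 nM, the first actual number for a group at this place, on a saturated chain carbon bound to a nitrogen on an aromatic ring. With 3,4-dichlorophenyl in place of 4-bromophenyl, the result is an at least 1.1-fold lower number from compound 2 to compound 3 (0.05 log units; that floor lies within the scatter), so the data do not separate these two groups. Compound 2 still stands only at a limit of the assay and not at a number: the limit of > 166000 nM in this assay, at which 1 of the 3 values shown sits.

The change from 2-chlorophenyl to 3,4-dichlorophenyl cannot be read, with compound 1 carrying no result. The compounds shown leave open whether an amine or a carboxylic acid on the phenyl ring, or a longer chain in place of the benzyl group, would give a clearly lower number in this assay.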